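The compounds below may be only part of what the source reports. "The series", "measured", "known", "first", "only" and "open" are said of these compounds alone.

For the measured compounds named here, compound 2 `COc1ncnc2c1c(-c1ccoc1)cn2[C@@H]1O[C@H](CO)[C@@H](O)[C@H]1O` is one of three compounds so far tested in a functional assay on CEM-DNR-bulk cells (Homo sapiens), read by MTT assay, with a stated time of 72 h; a lower number here means a stronger inhibitor, a higher number a weaker inhibitor. In this assay compound 2 reaches only > 20000 nM, which is a limit of the assay and not a number. Compound 1 `COc1ncnc2c1c(-c1ccsc1)cn2[C@@H]1O[C@H](CO)[C@@H](O)[C@H]1O` carries thiophen-3-yl where compound 2 carries furan-3-yl. In this assay compound 1 gives 7640 nM. Compound 3 `Cc1ncnc2c1c(-c1ccoc1)cn2[C@@H]1O[C@H](CO)[C@@H](O)[C@H]1O` carries methyl in place of the methoxy of compound 2. In this assay compound 3 also sits at > 20000 nM, again a limit rather than a number. The change leading to compound 4 `COc1ncnc2c1c(-c1cccs1)cn2[C@@H]1O[C@H](CO)[C@@H](O)[C@H]1O` is thiophen-2-yl in place of furan-3-yl on an aromatic carbon. Going by the values given here, only one measured step bears on it: an at least 2.6-fold higher number from compound 1 to compound 2 (0.41 log units; beyond the scatter), a move in the opposite direction, from thiophen-3-yl to furan-3-yl, that weakened inhibition. The step that the two limits leave unreadable from compound 2 to compound 3 offers nothing here, because the limit of > 20000 nM in this assay, at which 2 of the 3 values shown sit, hides its size. Among the compounds with values here, no measured pair compares thiophen-2-yl with thiophen-3-yl, so the expectation rests only on thiophen-2-yl replacing furan-3-yl. Compound 4 is therefore expected to improve, with the step of an at least 2.5-fold lower number from compound 2 to compound 4 (0.39 log units; beyond the scatter) pointing toward a stronger inhibitor. The estimate for compound 4 is 8000 nM, within a range from 3000 nM to 20000 nM, and a result that again stops at a limit is still possible.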

Compound 4, half-maximal inhibitory concentration: 12100 nM
The estimate for compound 4 lay 1.5-fold (0.18 log units) below the measured number, within the range that was stated.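

Placing thiophen-2-yl instead of furan-3-yl on this aromatic carbon turns a result with no readable number into a measured one in this assay, with an at least 1.6-fold lower number from compound 2 to compound 4 (0.21 log units; that floor lies within the scatter). The full size of that step stays hidden because compound 2 has only a limit of the assay and not a number: the limit of > 20000 nM in this assay, at which 2 of the 4 values shown sit. Thiophen-2-yl and thiophen-3-yl, on the same carbon of the same core, are not separated, with a 1.6-fold higher number from compound 1 to compound 4 (0.20 log units; within the scatter), so for this pair the point at which the thiophene ring is attached makes no readable difference.

As far as these compounds go, it remains open whether furan-2-yl or a phenyl ring on this carbon would also give a measured number, and a furan-2-yl result would help show whether the sulfur-containing ring or the point of attachment sets the two thiophene compounds apart from compound 2. Also open, from the compounds shown here alone, is what an amine in place of the methoxy would do alongside a thiophene ring, since the step from methoxy to methyl runs between two limits and cannot be read.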